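The source may report more compounds than this note shows. Statements on the series, on what has been measured and on what is new or still open speak of the compounds shown alone.

Measured in a functional assay on A549 cells (Homo sapiens) for antiproliferative activity, read by CCK-8 assay, with a stated time of 48 h; on this read-out lower numbers stand for stronger inhibition and higher numbers for weaker inhibition:

- compound 1 `O=c1c2ccccc2[se]n1-c1nnc(-c2cccc([N+](=O)[O-])c2)s1`: 16100 nM
- compound 2 `COc1cc(-c2nnc(-n3[se]c4ccccc4c3=O)s2)cc(OC)c1OC`: 3240 nM
- compound 3 `O=c1c2ccccc2[se]n1-c1nnc(-c2ccc(Cl)cc2)s1`: 10400 nM

Compound 3 gives the second highest of the three numbers in this assay. Its nearest neighbour is compound 1, whose number is higher by an amount that stays within the scatter of repeated measurements, so the two cannot be told apart. Compound 2 stands furthest away, with a lower number that lies beyond the scatter.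

The next compound in the series is compound 4 `O=c1c2ccccc2[se]n1-c1nnc(-c2ccc(F)cc2)s1`. Relative to compound 3 the change is fluoro in place of chloro on an aromatic carbon. Among the compounds with values here, no pair of measured compounds shows what this exchange does in this assay, so there is no directly comparable step to lean on. With one halogen swapped for another at the same place, and the shared core of compound 3 otherwise untouched, the step from compound 3 to compound 4 is expected to be small, with no clear direction and likely not beyond the scatter: a 1.2-fold higher number from compound 3 to compound 4 (0.06 log units; within the scatter). Compound 4 is therefore estimated to give about 12000 nM in this assay, with a range from 5000 nM to 30000 nM.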

Compound 4, half-maximal inhibitory concentration: 21100 nM
Estimate against measurement, compound 4: 1.8-fold (0.25 log units) below, and the stated range covers the measured number.
By their numbers in this assay, from the lowest: compound 2; then compounds 3, 1 and 4 (each within the scatter of the next, the first and the last beyond it).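

Within the data shown here, compounds 3 and 4 are the only pair here that differs in one place, which gives the series its first direct reading at this position in this assay: a 2.0-fold higher number from compound 3 to compound 4 (0.31 log units; beyond the scatter). The site on the aromatic carbon para to a large group is therefore not fully indifferent to the choice of halogen, though the step is modest and lies only just beyond the scatter. No available evidence bears on the origin of this step.

As far as these compounds go, with only chloro and fluoro compared at this place, it remains open whether bromo, an amine or a carboxylic acid at the same carbon would move the number further, and in which direction. Also open, from the compounds shown here alone, is whether the fluoro for chloro exchange gives a step of similar size at another carbon of that ring.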